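Amide series: pyridin-3-yl to pyridin-4-yl on the amide nitrogen

A few compounds are considered here, and "the series" means these few. Any claim that something is new, unique, unknown or untested is made for them only; others in the source may bear on it.

Measured in an assay on isolated protein for inhibition of phosphodiesterase 4A (Sus scrofa); a lower number here means a stronger inhibitor, a higher number a weaker inhibitor:
compound 1 `COc1ccc(C(=O)Nc2c(C)cccc2Cl)cc1OC1CCCC1` gives 100 nM
compound 2 `COc1ccc(C(=O)Nc2cccnc2)cc1OC1CCCC1` gives 550 nM

Compound 2 stands highest of the two numbers; compound 1 is the nearest, separated by the step of a 5.5-fold higher number from compound 1 to compound 2 (0.74 log units; beyond the scatter). Compound 3 `COc1ccc(C(=O)Nc2ccncc2)cc1OC1CCCC1` differs from compound 2 by pyridin-4-yl in place of pyridin-3-yl on an amide-type nitrogen. Among the measured compounds shown here, no measured step moves the ring nitrogen within a pyridyl group; the one step known, a 5.5-fold higher number from compound 1 to compound 2 (0.74 log units; beyond the scatter), exchanges the whole aryl group and only shows that this position can shift the number. The step of a 1.2-fold lower number from compound 2 to compound 3 (0.09 log units; within the scatter) is therefore expected to stay near the scatter, direction open. Compound 3 is estimated at 450 nM, within 150 nM to 1500 nM.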

Compound 3, half-maximal inhibitory concentration: 800 nM
Compound 3: the middle estimate sits 1.8-fold (0.25 log units) below what was measured; low and high end bracket the measured number.
By their numbers in this assay, from the lowest: compound 1; then compounds 2 and 3 (each within the scatter of the next).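

In this assay, moving the ring nitrogen within the pyridyl group on the amide-type nitrogen gives a 1.5-fold higher number from compound 2 to compound 3 (0.16 log units; within the scatter), so this change does not separate pyridin-4-yl from pyridin-3-yl. The gap to the 2-chloro-6-methylphenyl group holds for the second pyridyl group too, with an 8.0-fold higher number from compound 1 to compound 3 (0.90 log units; beyond the scatter). No supporting data bear on the reason for either step.

Open, going by these compounds, is whether pyridin-2-yl or unsubstituted phenyl on the same nitrogen would fall with compound 1 or with the two pyridyl compounds. Also open, on these data alone, is how much of the gap belongs to the chloro group and how much to the methyl group.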